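The source may report more compounds than this note shows. Statements on the series, on what has been measured and on what is new or still open speak of the compounds shown alone.

Within the data shown here, in an in vitro ADME assay on microsomes from liver (Simiiformes) (a lower number here means that the compound disappears faster, a higher number that the compound lasts longer), compound 3, `Cc1cc(CCCOc2c(C)cc(-c3noc(C(Cl)(Cl)Cl)n3)cc2C)on1`, gives 0.183 h, the only value in this small set that is an actual number. Compound 4, `Cc1cc(CCCOc2c(C)cc(-c3noc(C4CC4)n3)cc2C)on1`, puts cyclopropyl in place of trichloromethyl on an aromatic carbon. Compound 1, `COCc1cc(CCCOc2c(C)cc(-c3noc(C4CC4)n3)cc2C)on1`, also carries cyclopropyl, and its > 2.5 h is a limit of the assay. Compound 2, `CCOc1cc(CCCOc2c(C)cc(-c3noc(C4CC4)n3)cc2C)on1`, carries cyclopropyl as well, and its > 2.5 h is the same limit. Among the measured compounds shown here, the one measured step, a step that the two limits leave unreadable from compound 1 to compound 2, offers no size to carry over, so only those two limits bear on the change. On that ground, a clear rise in half-life is expected, a 16-fold higher number from compound 3 to compound 4 (1.21 log units; beyond the scatter). For compound 4 the estimated half-life is 3 h, with an expected range of 1.2 h to 7 h.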

Compound 4, half-life: 2.23 h
Compound 4: the middle estimate sits 1.3-fold (0.13 log units) above what was measured; the range from low to high includes it.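

In this assay, cyclopropyl in place of trichloromethyl gives a 12-fold higher number from compound 3 to compound 4 (1.09 log units; beyond the scatter), so the group at this place on the shared core alone changes the half-life substantially. The other two new steps are an at least 1.1-fold lower number from compound 2 to compound 4 (0.04 log units; that floor lies within the scatter) and an at least 1.1-fold lower number from compound 1 to compound 4 (0.04 log units; that floor lies within the scatter). Both start from a limit of the assay, so they fix no size and no order among these compounds: the limit of > 2.5 h in this assay, at which 2 of the 4 values shown sit.

On these data alone, whether the rise belongs to cyclopropyl itself or would follow with any replacement of trichloromethyl stays open. So does what an ethyl, a trifluoromethyl or an amine would give at this place.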